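One aryl group exchanged, cytotoxicity still to be read

A few compounds are considered here, and "the series" means these few. Any claim that something is new, unique, unknown or untested is made for them only; others in the source may bear on it.

Compound 1, `COc1nc2ccc(Br)cc2cc1C(c1ccccc1)n1cc(-c2ccc(Br)cc2)nn1`, gives 6.28% in an ADME assay on HEK293 cells (Homo sapiens) for cytotoxicity, read by sulforhodamine B assay, with a stated time of 48 h, tested at 10 uM; a lower number here means less inhibition, a higher number more inhibition at the concentration tested (going by the name of the read-out).
Compound 2, `CCCCCCCc1cn(C(c2ccccc2)c2cc3cc(Br)ccc3nc2OC)nn1`, gives 0.17%.
Compound 3, `COc1nc2ccc(Br)cc2cc1C(c1ccccc1)n1cc(CO)nn1`, gives 11.5%.

Among these three numbers compound 1 stands second highest; compound 3 lies nearest to it and compound 2 furthest, and both gaps are within the scatter. Compound 4, `COc1nc2ccc(Br)cc2cc1C(c1ccccc1)n1cc(-c2ccccc2C(F)(F)F)nn1`, differs from compound 1 by 2-(trifluoromethyl)phenyl in place of 4-bromophenyl on an aromatic carbon. Within the data shown here, the two steps that change the same group bear on this: a number 6.1 percentage points lower from compound 1 to compound 2 (within the scatter) and a number 5.2 percentage points higher from compound 1 to compound 3 (within the scatter), neither of them beyond the scatter, while a number 11.3 percentage points higher from compound 2 to compound 3 (beyond the scatter) is the only modest step among the measured pairs. An exchange of one aryl group for another at this place is therefore expected to give no step beyond the scatter, a number 0.7 percentage points higher from compound 1 to compound 4 (within the scatter). Compound 4 is expected to show 7%, with a range from -5% to 20%.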

Compound 4, a percentage reported as inhibition, at one concentration (the size of the read-out at that concentration, not a potency): 14.3%
The estimate for compound 4 lay 7.3 percentage points below the measured number; low and high end bracket the measured number.
By their numbers in this assay, from the lowest: compounds 2, 1, 3 and 4 (each within the scatter of the next, the first and the last beyond it).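

The 2-(trifluoromethyl)phenyl group at this aromatic carbon gives no step beyond the scatter against 4-bromophenyl (a number 8 percentage points higher from compound 1 to compound 4 (within the scatter)) or hydroxymethyl (a number 2.8 percentage points higher from compound 3 to compound 4 (within the scatter)) in this assay. Against heptyl it gives a second modest step beyond the scatter (a number 14.1 percentage points higher from compound 2 to compound 4 (beyond the scatter)), so compound 2 now stands apart from both compound 3 and compound 4, though not from compound 1. No measurement shown here accounts for these numbers. Open, going by these compounds, is whether an amine, a carboxylic acid or a chain longer than heptyl at this place would give a step beyond the scatter from compound 1.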